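The source may hold more compounds than are shown below. What is called first, only, known or untested is meant among the compounds shown, and "the series" means these compounds.

Three compounds share a core in which a thioether-linked ketone arm and an aniline arm hang from the same central ring, and each has been tested in a functional assay on MDA-MB-231 cells (Homo sapiens) for inhibition, read by sulforhodamine B assay, with a stated time of 48 h, tested at 10 uM; on this read-out lower numbers stand for less inhibition of growth and higher numbers for more inhibition of growth at the one concentration tested. Compound 1 `O=C(O)c1ccc(Nc2ccnc(SCC(=O)c3ccc(C(F)(F)F)cc3)n2)cc1` gives 24%. Compound 2 `CCOC(=O)c1ccc(Nc2ccnc(SCC(=O)c3ccc(C#N)cc3)n2)cc1` gives 19%. Compound 3 `CC(=O)c1cccc(Nc2ccnc(SCC(=O)c3ccc(-c4ccccc4)cc3)n2)c1` gives 41%, the highest of the three numbers; its nearest neighbour is compound 1, and both that gap and the gap to compound 2 lie beyond the usual scatter. Compound 1 and compound 2 differ from compound 3 in more than one place, so their numbers only show where they stand, not what any single change does.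

Compound 4 `COc1ccc(C(=O)CSc2nccc(Nc3cccc(C(C)=O)c3)n2)cc1` differs from compound 3 in one place: methoxy in place of phenyl on an aromatic carbon, on an aromatic carbon, para to a large group. Within the data shown here, no measured pair with a single change is available, so the expectation rests on the three values alone. Because compound 3 gives 41% and the two compounds with smaller groups at that position give lower numbers, a downward step is expected, a number 16 percentage points lower from compound 3 to compound 4 (beyond the scatter). Compound 4 is therefore estimated at 25%, within a range from 10% to 42%.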

Compound 4, percent growth inhibition at one concentration: 27%
Compound 4: middle estimate off by 2 percentage points, on the low side, and the stated range covers the measured number.
By their numbers in this assay, from the lowest: compounds 2, 1 and 4 (each within the scatter of the next); then compound 3.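

In this assay, among these compounds, replacing phenyl with methoxy on an aromatic carbon, para to a large group, gives a number 14 percentage points lower from compound 3 to compound 4 (beyond the scatter), the first reading of a single change at this position. The position is therefore not indifferent to what it carries: the group that leaves has 6 heavy atoms and a ring, while the one that enters has 2 heavy atoms, no ring and one hydrogen-bond acceptor. Nothing measured here explains the drop.

This single pair cannot separate losing the ring from gaining the oxygen, and a methyl group, a longer alkyl chain or an amine in the same place could help to tell them apart. From the compounds shown here alone, whether the step holds with a different group on the aniline arm also remains open.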